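The source may hold more compounds than are shown below. What is called first, only, known or untested is meant among the compounds shown, and "the series" means these compounds.

Compound 1 `CCOC(=O)CN1C(=O)S/C(=C\c2ccc(-c3ccc(Cl)cc3Cl)o2)C1=O`: 13600 nM
Compound 2 `CCOC(=O)CN1C(=O)S/C(=C\c2ccc(N3CCCC3)o2)C1=O`: 23200 nM
Compound 3 `COC(=O)CN1C(=O)S/C(=C\c2ccc(Sc3ccccc3)o2)C1=O`: reported only as "not active" (no number reported)

In a functional assay on K562 cells for agonist activity at integrin alpha-M/beta-2 (Homo sapiens) (on this read-out lower numbers stand for an effect already at smaller amounts and higher numbers for an effect only at larger amounts of compound), compound 2 gives the higher of the two numbers, and its nearest neighbour is compound 1, with a 1.7-fold higher number from compound 1 to compound 2 (0.23 log units; within the scatter) separating them, so the two cannot be told apart. Compound 3 has no number at all. Compound 4 `CCOC(=O)CN1C(=O)S/C(=C\c2ccc(-c3ccc(Br)cc3)o2)C1=O` arises from compound 2 by a change on the furan-type ring: 4-bromophenyl in place of pyrrolidin-1-yl on an aromatic carbon. Going by the values given here, the only step that bears on it is a 1.7-fold higher number from compound 1 to compound 2 (0.23 log units; within the scatter), which swapped an aromatic carbon ring for pyrrolidin-1-yl and stayed within the scatter. Returning to an aromatic carbon ring is therefore expected to give at most a small move downward, a 2.1-fold lower number from compound 2 to compound 4 (0.32 log units; beyond the scatter), and compound 4 is estimated at 11000 nM, between 4000 nM and 40000 nM.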

Compound 4, half-maximal effective concentration: 40400 nM
Compound 4: middle estimate off by 3.7-fold (0.56 log units), on the low side; measured number outside the range, above it.
By their numbers in this assay, from the lowest: compounds 1, 2 and 4 (each within the scatter of the next, the first and the last beyond it).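

In this assay, 4-bromophenyl in place of pyrrolidin-1-yl gives a 1.7-fold higher number from compound 2 to compound 4 (0.24 log units; within the scatter), so a non-aromatic ring and a carbon-only aromatic ring cannot be told apart at this position. Going by these compounds alone, changing only the halogens on the phenyl ring, 4-bromophenyl in place of 2,4-dichlorophenyl, gives a 3.0-fold higher number from compound 1 to compound 4 (0.47 log units; beyond the scatter), the first step here beyond the scatter, though a modest one. No measurement at hand explains either step. Still open, from the compounds shown here alone, is how an unsubstituted phenyl, a morpholine or a carboxylic acid would behave at this position.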